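Triazole aryl swaps in a spiro oxindole series

The source may report more compounds than this note shows. Statements on the series, on what has been measured and on what is new or still open speak of the compounds shown alone.

Compound 1, `Cc1ccccc1-n1nncc1CN1C(=O)C2(C(C#N)=C(N)Oc3c2c2nc4ccccc4nc2c2ccccc32)c2ccccc21`: in a functional assay on HepG2 cells (Homo sapiens) for antiproliferative activity, read by MTT assay, with a stated time of 48 h (a lower number here means a stronger inhibitor, a higher number a weaker inhibitor), compound 1 gives > 50000 nM, a limit of the assay.
Compound 2, `Cc1cc(C)cc(-n2nncc2CN2C(=O)C3(C(C#N)=C(N)Oc4c3c3nc5ccccc5nc3c3ccccc43)c3ccccc32)c1`: in this assay compound 2 gives > 50000 nM, also a limit.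
Compound 3, `Cc1ccc(-n2nncc2CN2C(=O)C3(C(C#N)=C(N)Oc4c3c3nc5ccccc5nc3c3ccccc43)c3ccccc32)c(C)c1`: in this assay compound 3 gives > 50000 nM, again a limit.

Compound 3 thus stands at the same limit as the other two values shown, (the limit of > 50000 nM in this assay, at which 3 of the 3 values shown sit). The measured steps a step that the two limits leave unreadable from compound 1 to compound 2, a step that the two limits leave unreadable from compound 1 to compound 3 and a step that the two limits leave unreadable from compound 2 to compound 3 cannot be sized, since both ends of each sit at that limit. Compound 4, `N#CC1=C(N)Oc2c(c3nc4ccccc4nc3c3ccccc23)C12C(=O)N(Cc1cnnn1-c1ccc(F)c(Cl)c1)c1ccccc12`, carries the change (3-chloro-4-fluorophenyl in place of 2,4-dimethylphenyl on an aromatic nitrogen). Among the measured compounds shown here, no measured step bears readably on this change, so the expectation rests on the three limits alone: compound 4 is expected to remain at or near the limit, with a step that the limit leaves unreadable from compound 3 to compound 4 as the expected step. The estimate for compound 4 in this assay is 60000 nM, within 10000 nM to 200000 nM.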

Compound 4, half-maximal inhibitory concentration: > 50000 nM
Compound 4: no number, only a limit; the forecaster's own chance of this, stated with the estimate: 80%; the middle value does not contradict the limit.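

The steps from compound 1, compound 2 and compound 3 to compound 4 cannot be read, as all four compounds sit at one limit: the limit of > 50000 nM in this assay, at which 4 of the 4 values shown sit.

The compounds shown leave open whether any aryl group at this place gives a measurable value.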